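Triple Bond in the Side Chain: Toxicity of Compound 4

A few compounds are considered here, and "the series" means these few. Any claim that something is new, unique, unknown or untested is made for them only; others in the source may bear on it.

Compound 1, `CCCCCCC#Cc1cc2cn(COCCO)c(=O)nc2o1`: in a functional assay on HEL cells (Homo sapiens) (on this read-out lower numbers stand for higher toxicity in this test and higher numbers for lower toxicity in this test), compound 1 gives > 50000 nM, a limit of the assay.
Compound 2, `CCCCCCCc1cc2cn(COCCO)c(=O)nc2o1`: in this assay compound 2 gives 140000 nM.
Compound 3, `CCCCCCCCCc1cc2cn(COCCO)c(=O)nc2o1`: in this assay compound 3 gives >= 100000 nM, again a limit.

Compound 2 is the only one of the three with an actual number; the others are limits. Compound 1 sits at the limit of > 50000 nM in this assay, at which 1 of the 3 values shown sits. Compound 3 sits at the limit of >= 100000 nM in this assay, at which 1 of the 3 values shown sits. Within the data shown here, the one measured step, a step that the limit leaves unreadable from compound 2 to compound 3, is therefore unreadable. Compound 4, `CCCCCC#Cc1cc2cn(COCCO)c(=O)nc2o1`, carries hept-1-yn-1-yl in place of heptyl on an aromatic carbon. Among the measured compounds shown here, no measured step covers a triple bond directly, and compound 1, which also has a triple bond, shows only a limit. For compound 4 the expected step is a 1.2-fold lower number from compound 2 to compound 4 (0.07 log units; within the scatter), no change beyond the scatter. Compound 4 is estimated at 120000 nM, between 40000 nM and 300000 nM.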

Compound 4, half-maximal cytotoxic concentration: > 50000 nM
Compound 4 ended at the assay's limit; the forecaster's own chance of this, stated with the estimate: 60%; the middle value lies beyond the limit too.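

Neither the step from compound 2 to compound 4 nor the step from compound 1 to compound 4 can be read, because compound 4 gives only a limit: the limit of > 50000 nM in this assay, at which 2 of the 4 values shown sit.

The compounds shown leave open whether a triple bond in the side chain changes the result in this assay at all.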